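A few compounds are considered here, and "the series" means these few. Any claim that something is new, unique, unknown or untested is made for them only; others in the source may bear on it.

Compounds measured so far:
Compound 1, `Cc1cccc(N2N=C(C(C)(C)C)CC2c2ccc(O)cc2)c1` — 3500 nM
Compound 2, `Oc1ccc(C2CC(c3ccccc3)=NN2c2ccc(Cl)cc2)cc1` — 3500 nM
Compound 3, `Oc1ccc(C2CC(c3ccccc3)=NN2c2cccc(Cl)c2)cc1` — 2100 nM

In an assay on isolated protein for inhibition of protein kinase C zeta type (Homo sapiens), with a stated time of 4 min (a higher number here means a weaker inhibitor, a lower number a stronger inhibitor), compound 2 gives 3500 nM. That places it level with compound 1, the two of them sitting together at the highest numbers of the three; compound 3 gives 2100 nM, and the step of a 1.7-fold lower number from compound 2 to compound 3 (0.22 log units; within the scatter) stays within the usual scatter, so none of the three can be ranked against the others.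

The unmeasured compound 4, `Oc1ccc(C2CC(c3ccccc3O)=NN2c2ccc(Cl)cc2)cc1`, keeps the core of compound 2 and alters only the phenyl ring on the ring carbon: hydroxy in place of hydrogen on an aromatic carbon. Read one bond further out, this is phenyl to 2-hydroxyphenyl.

Among the compounds with values here, none of the measured steps touches that phenyl ring; the only step available, from compound 2 to compound 3, moves the chloro on the other ring and is itself within the scatter. Within the data shown here, with no precedent for adding a hydroxy there, the expected step of a 1.2-fold lower number from compound 2 to compound 4 (0.07 log units; within the scatter) is none beyond the scatter. Compound 4 is therefore estimated at 3000 nM in this assay, within a range from 1200 nM to 8000 nM.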

Compound 4, half-maximal inhibitory concentration: 1500 nM
Compound 4: middle estimate off by 2.0-fold (0.30 log units), on the high side; low and high end bracket the measured number.
By their numbers in this assay, from the lowest: compounds 4, 3, 1 and 2 (each within the scatter of the next, the first and the last beyond it).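

Within the data shown here, this is the first change to the phenyl ring on the ring carbon, and in this assay hydroxy in place of hydrogen gives a 2.3-fold lower number from compound 2 to compound 4 (0.37 log units; beyond the scatter), a modest step. It is also the first single change among these compounds to pass beyond the scatter, which shows that the number can respond to a change at this ring, whereas the earlier move of the chloro on the other ring, a 1.7-fold lower number from compound 2 to compound 3 (0.22 log units; within the scatter), did not show a clear difference. Nothing available bears on the reason for the step to 2-hydroxyphenyl.

Still open, going by these compounds, is how other groups in the same place, such as methoxy, an amine or a carboxylic acid, would compare with hydroxy. Also open, on these data alone, is whether the same hydroxy would give a similar step alongside the 3-chlorophenyl of compound 3.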